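This account rests on a few compounds, and the source may have more. Where it says the series, first, only, none or still open, it means among the compounds named here.

Compound 1 `Oc1cccc(-c2cc(-c3cccs3)cc(-c3ccccc3O)n2)c1` carries a thiophen-2-yl group on its core. In a functional assay on T47D cells (Homo sapiens) for cytotoxicity, read by CCK-8 assay (a lower number here means a stronger inhibitor, a higher number a weaker inhibitor), compound 1 gives only a limit of the assay, > 50000 nM. Compound 2 `Oc1cccc(-c2cc(-c3cccs3)cc(-c3cccc(O)c3)n2)c1` differs from it by 3-hydroxyphenyl in place of 2-hydroxyphenyl on an aromatic carbon. In this assay compound 2 gives 770 nM. The change made an at least 64-fold lower number from compound 1 to compound 2 (1.81 log units; beyond the scatter), and its true size is capped by the limit of > 50000 nM in this assay, at which 2 of the 3 values shown sit.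

Compound 3 `Oc1ccccc1-c1cc(-c2ccccn2)cc(-c2ccccc2O)n1` carries a pyridin-2-yl group; how its core differs from the core of compound 1 is not broken down here. In this assay compound 3 gives only a limit, > 50000 nM. Compound 4 `Oc1cccc(-c2cc(-c3ccccn3)cc(-c3ccccc3O)n2)c1` is not yet measured and differs from compound 3 by 3-hydroxyphenyl in place of 2-hydroxyphenyl on an aromatic carbon. This is the same kind of change as before, though the place differs: earlier it was meta to a 3-hydroxyphenyl group and meta to a thiophen-2-yl group, here it is meta to a 2-hydroxyphenyl group and meta to a pyridin-2-yl group. For compound 4 the expected step is an at least 16-fold lower number from compound 3 to compound 4 (1.22 log units; beyond the scatter), resting on an at least 64-fold lower number from compound 1 to compound 2 (1.81 log units; beyond the scatter). Compound 4 is estimated at 3000 nM in this assay, expected between 500 nM and 50000 nM.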

Compound 4, half-maximal inhibitory concentration: 2560 nM
Compound 4: middle estimate off by 1.2-fold (0.07 log units), on the high side; measured number inside the range.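

On the core of compound 3, 3-hydroxyphenyl in place of 2-hydroxyphenyl gives in this assay an at least 19-fold lower number from compound 3 to compound 4 (1.29 log units; beyond the scatter), so the change points the same way on both cores shown. This shows that the direction carried from one core to the other, but not that the size did: the same change on two cores in this assay, an at least 64-fold lower number (1.81 log units; beyond the scatter) from compound 1 to compound 2 and an at least 19-fold lower number (1.29 log units; beyond the scatter) from compound 3 to compound 4; the limit leaves it open whether they differ Both steps start from a limit of the assay rather than a true number, so neither step has a known full size: the limit of > 50000 nM in this assay, at which 2 of the 4 values shown sit.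

Pyridin-2-yl in place of thiophen-2-yl gives an at least 19-fold lower number from compound 1 to compound 4 (1.29 log units; beyond the scatter), but this step also starts from a limit, and it is only one swap on one core, so it sets no general rule for that position. The compounds shown leave open how a pyridin-2-yl compound carrying two 3-hydroxyphenyl groups would compare with compound 2, and what an amine or a carboxylic acid in place of the hydroxyl group would do.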